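A few compounds are considered here, and "the series" means these few. Any claim that something is new, unique, unknown or untested is made for them only; others in the source may bear on it.

Compound 3 `Cc1ncn2c(NN)nncc12` carries an aminoamino group on its core. In a functional assay for inhibition, with Homo sapiens as the target (a higher number here means a weaker inhibitor, a lower number a stronger inhibitor), compound 3 reaches only the limit of the assay, > 48000 nM, and not a number. Compound 1 `CCc1ncn2c(O)nncc12` likewise gives only a limit in this assay, > 48000 nM. Compound 2 `COCc1nc(C)c2cnnc(S)n12`, which already bears a sulfanyl group, also stops at a limit in this assay, > 48000 nM. Compound 3 therefore stands apart from nothing, since every value shown sits at the limit of > 48000 nM in this assay, at which 3 of the 3 values shown sit. Compound 4 `Cc1ncn2c(S)nncc12` differs from compound 3 in one place: sulfanyl in place of aminoamino on an aromatic carbon. Within the data shown here, no measured step bridges this change. The step that the limit leaves unreadable from compound 3 to compound 4 is expected to be none beyond the scatter, most likely ending at the limit once more. Compound 4 is accordingly estimated at 60000 nM, between 20000 nM and 200000 nM.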

Compound 4, half-maximal inhibitory concentration: > 48000 nM
Compound 4: no number, only a limit; the forecaster's own chance of this, stated with the estimate: 80%; the middle value does not contradict the limit.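

Compound 4 also gives only a limit in this assay, > 48000 nM, so neither the change from compound 3 nor that from compound 2 to compound 4 can be read as a step. The compounds shown leave open which change to the shared core, if any, would give a measurable value.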